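Methyl to ethyl on the piperazine of compound 3

The compounds below may be only part of what the source reports. "The series", "measured", "known", "first", "only" and "open" are said of these compounds alone.

Compound 3 `CN1CCN(CC(=O)Nc2ccc(-c3nc(-c4ccccc4)c(-c4ccccc4)n3C)cc2)CC1` stands lowest of the three measured numbers in a functional assay on HT-29 cells (Homo sapiens) for cytotoxicity, read by MTT assay, with a stated time of 24 h, tested at 80 ug/mL; a lower number here means a weaker effect, a higher number a stronger effect of the compound at the concentration tested; compound 3 gives 53.1%. Compound 1 `Cn1c(-c2ccc(NC(=O)CSc3nc4cc(Cl)ccc4o3)cc2)nc(-c2ccccc2)c1-c1ccccc1` gives 79.6% in this assay, and compound 2 `Cn1c(-c2ccc(NC(=O)CSC3=NCCS3)cc2)nc(-c2ccccc2)c1-c1ccccc1` gives 75.2%. The step of a number 26.5 percentage points lower from compound 1 to compound 3 (beyond the scatter) and the step of a number 22.1 percentage points lower from compound 2 to compound 3 (beyond the scatter) both set compound 3 beyond the scatter below the other two, whereas a number 4.4 percentage points lower from compound 1 to compound 2 (within the scatter) lies within it.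

Compound 4 `CCN1CCN(CC(=O)Nc2ccc(-c3nc(-c4ccccc4)c(-c4ccccc4)n3C)cc2)CC1` carries methyl in place of hydrogen on a saturated chain carbon bound to an amine nitrogen in a ring. Going by the values given here, none of the measured steps touches this place: the steps that lead to compound 3 exchange the whole group on the saturated chain carbon bound to the carbonyl carbon, not a hydrogen on the 4-methylpiperazin-1-yl. The change from methyl to ethyl is small, and no shown step gives a size for it; the expectation is therefore no step beyond the scatter in this assay, in either direction. For compound 4 the estimate is 53% (40% to 66%), an expected step of a number 0.1 percentage points lower from compound 3 to compound 4 (within the scatter).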

Compound 4, a percentage reported as activity, at one concentration (the size of the read-out at that concentration, not a potency): 51.2%
For compound 4 the middle estimate is 1.8 percentage points above the measured one, and the stated range covers the measured number.
By their numbers in this assay, from the lowest: compounds 4 and 3 (each within the scatter of the next); then compounds 2 and 1 (each within the scatter of the next).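

In this assay, the step from methyl to ethyl on the 4-methylpiperazin-1-yl reads as a number 1.9 percentage points lower from compound 3 to compound 4 (within the scatter) and is the first step shown at this place, so methyl in place of hydrogen on a saturated chain carbon bound to an amine nitrogen in a ring does not move the number beyond the scatter. The 4-ethylpiperazin-1-yl group stays apart from the two sulfur-linked groups, with a number 24 percentage points lower from compound 2 to compound 4 (beyond the scatter) and a number 28.4 percentage points lower from compound 1 to compound 4 (beyond the scatter), so among these compounds the steps beyond the scatter go with exchange of the whole group on the saturated chain carbon bound to a carbonyl carbon. No supporting measurement is available to explain either the flat step or the larger ones.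

On these data alone, whether a longer chain such as n-butyl or benzyl on this ring nitrogen would also stay within the scatter remains open. Also open, as far as these compounds go, is what a morpholine ring or a free secondary amine would give in place of the 4-ethylpiperazin-1-yl.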